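The source may report more compounds than this note shows. Statements on the series, on what has been measured and on what is new or still open speak of the compounds shown alone.

In a functional assay on PANC-1 cells (Homo sapiens), read by microscopy, crystal violet staining and transwell migration, with a stated time of 18 h, in the presence of a further agent that is not named here (a lower number here means a stronger inhibitor, a higher number a weaker inhibitor), compound 1 `COc1ccc(-c2nc(C)nn2-c2cccc(C(=O)NCCCc3ccc(Br)cc3)c2)cc1` gives > 20000 nM, which is a limit of the assay and not a number. Compound 2 `COc1ccc(-c2nc(C(C)C)nn2-c2cccc(C(=O)NCCCCc3ccccc3)c2)cc1` gives > 20000 nM, also a limit. For the measured compounds named here, compound 3 `CCc1nc(-c2ccc(OC(F)F)cc2)n(-c2cccc(C(=O)NCCCCc3ccccc3)c2)n1` is therefore the only compound of the three with a measured number, at 830 nM. Activity is thus the exception in this small set, which shows (the limit of > 20000 nM in this assay, at which 2 of the 3 values shown sit).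

Compound 4 `CCc1nc(-c2ncc(OC)cn2)n(-c2cccc(C(=O)NCCCCc3ccccc3)c2)n1` keeps the rest of compound 3 and changes one group: 5-methoxypyrimidin-2-yl stands in place of 4-(difluoromethoxy)phenyl on an aromatic carbon (5-methoxypyrimidin-2-yl in place of 4-(difluoromethoxy)phenyl on an aromatic carbon). Going by the values given here, no pair of measured compounds differs in one place only, so the data offer no direct precedent for this swap. Among the compounds with values here, with compound 3 at 830 nM as the only number to start from, a weaker result seems more likely than a stronger one. The expected change is a loss of potency beyond the usual scatter, estimated as a 3.6-fold higher number from compound 3 to compound 4 (0.56 log units; beyond the scatter). Compound 4 is expected at about 3000 nM, with an estimated range from 600 nM to 20000 nM.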

Compound 4, half-maximal inhibitory concentration: 110 nM
Compound 4: the middle estimate sits 27-fold (1.44 log units) above what was measured, and the stated range ends above it.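

In this assay, the aromatic carbon of the five-membered aromatic ring with 3 nitrogen, two ring bonds from the ring atom that bears an ethyl group, responds clearly to the group it carries: 5-methoxypyrimidin-2-yl in place of 4-(difluoromethoxy)phenyl gives a 7.5-fold lower number from compound 3 to compound 4 (0.88 log units; beyond the scatter). A six-membered aromatic ring of carbon only is therefore not needed here for a measured number, and a ring with 2 hetero atoms serves at this place with the rest of the molecule unchanged. The data shown give no reason for this gain.

As far as these compounds go, whether the ring nitrogens or the methoxy group carry the step stays open, as a 5-methoxypyridin-2-yl group would be needed to separate them. Also open, from the compounds shown here alone, is how a pyrimidin-2-yl group bearing an amine or a longer alkoxy chain in place of the methoxy group would behave at this position.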